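Swapping a methyl for hydrogen in compound 2

A few compounds are considered here, and "the series" means these few. Any claim that something is new, unique, unknown or untested is made for them only; others in the source may bear on it.

Of the compounds shown here, two have been measured so far. In a physicochemical assay for lipophilicity, read by HPLC, measured as chromatographic lipophilicity, at pH 7.4 (a higher number here means a more lipophilic compound, a lower number a more polar compound), compound 2 `CN1C(=O)[C@@H](NC(=O)c2n[nH]c(Cc3ccccc3)n2)CCc2ccccc21` gives 3.8, the higher of the two numbers. Compound 1 `O=C(N[C@H]1COc2ccccc2NC1=O)c1n[nH]c(Cc2ccccc2)n1` gives 3, and the gap between them lies beyond the usual scatter of repeated measurements.

Compound 3 `O=C(N[C@H]1CCc2ccccc2NC1=O)c1n[nH]c(Cc2ccccc2)n1` has not yet been measured. It differs from compound 2 in one place: hydrogen in place of methyl on an amide-type nitrogen in a ring. Within the data shown here, no measured pair shows this change on its own, so any expectation is rough. Compound 1 also carries hydrogen on an amide-type nitrogen in a ring, and its 3 points downward. A modest fall in this assay is therefore expected, an estimated a number 0.40 log units lower from compound 2 to compound 3 (beyond the scatter). Compound 3 is expected at 3.4, within a range of 3 to 3.8.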

Compound 3, distribution coefficient: 3.1
The estimate for compound 3 lay 0.30 log units above the measured number; the range from low to high includes it.
By their numbers in this assay, from the lowest: compounds 1 and 3 (each within the scatter of the next); then compound 2.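

Among these compounds, this pair gives the first direct reading of the change: with the rest of the structure unchanged, hydrogen in place of methyl on an amide-type nitrogen in a ring gives a number 0.70 log units lower from compound 2 to compound 3 (beyond the scatter) in this assay. The step shows that this single position, on a seven-membered non-aromatic ring, can shift the number beyond the scatter when only one carbon atom leaves. No measurement shown here explains why the number falls.

The compounds shown leave open how an ethyl group, a longer chain or a chain bearing an amine on this same nitrogen would read in this assay. They also leave open whether methyl in place of hydrogen on the amide-type nitrogen in the ring of compound 1 would give a step of similar size.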